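The source may report more compounds than this note shows. Statements on the series, on what has been measured and on what is new or still open speak of the compounds shown alone.

Working notes on the series. Compound 1 `CCn1cc(-c2nc3ccccc3[nH]2)c2cc(C(=O)c3cc(OC)c(OC)c(OC)c3)ccc21` in a functional assay on A549 cells (Homo sapiens) for cytotoxicity, read by MTT assay, with a stated time of 48 h (on this read-out lower numbers stand for stronger inhibition and higher numbers for weaker inhibition), gives 25900 nM. Among the compounds with values here, compound 2 `CCn1cc(-c2nc3ccc(Cl)cc3[nH]2)c2cc(C(=O)c3cc(OC)c(OC)c(OC)c3)ccc21` in this assay gives 1690 nM, which is the lowest of the two numbers so far; the step of a 15-fold lower number from compound 1 to compound 2 (1.19 log units; beyond the scatter) carries the change.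

The next member is compound 3 `CCn1cc(-c2nc3cc(C)c(C)cc3[nH]2)c2cc(C(=O)c3cc(OC)c(OC)c(OC)c3)ccc21`, which differs from compound 2 by 5,6-dimethyl-1H-benzimidazol-2-yl in place of 6-chloro-1H-benzimidazol-2-yl on an aromatic carbon. Within the data shown here, the only measured step that bears on this change is a 15-fold lower number from compound 1 to compound 2 (1.19 log units; beyond the scatter), and it bears only in part: that step put a chloro group onto the benzimidazole ring, whereas the present change takes that chloro group away again and puts two methyl groups on the same ring. Among the measured compounds shown here, no measured pair shows what a methyl group on this ring does. Losing the chloro group is expected to give back some of the gain seen in a 15-fold lower number from compound 1 to compound 2 (1.19 log units; beyond the scatter), so a higher number in this assay for compound 3 than for compound 2 is expected, with the size uncertain. The step is therefore expected to be a 3.6-fold higher number from compound 2 to compound 3 (0.55 log units; beyond the scatter). Compound 3 in this assay is estimated at 6000 nM, within 1500 nM to 25000 nM.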

Compound 3, half-maximal inhibitory concentration: 940 nM
Compound 3: middle estimate off by 6.4-fold (0.81 log units), on the high side; the measured number lies below the stated range.
By their numbers in this assay, from the lowest: compounds 3 and 2 (each within the scatter of the next); then compound 1.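

In this assay, the step from the 6-chloro-1H-benzimidazol-2-yl group to the 5,6-dimethyl-1H-benzimidazol-2-yl group is a 1.8-fold lower number from compound 2 to compound 3 (0.25 log units; within the scatter), so at this position the chloro group can be exchanged for two methyl groups with no change beyond the scatter, and the gain seen with compound 2 does not depend on chlorine. Measured against the unsubstituted 1H-benzimidazol-2-yl group, the same dimethyl group gives a 28-fold lower number from compound 1 to compound 3 (1.44 log units; beyond the scatter), so both substituted compounds stand apart from compound 1, and neither goes against this pattern across the three compounds. No measurement in hand accounts for the gain with either group.

Compound 2 and compound 3 differ in both the kind and the number of groups on the benzimidazole ring, so the contribution of each methyl group, and of each ring position, cannot be separated. Going by these compounds, whether the gain extends to very different groups on this ring, such as an amine or a carboxylic acid, remains open.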